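Pyridyl for Phenyl at Two Benzylic Positions in GnRH Antagonists

The compounds below may be only part of what the source reports. "The series", "measured", "known", "first", "only" and "open" are said of these compounds alone.

Compound 1, `COc1ccc([N+](=O)[O-])cc1CSc1nc2cc(NC(=O)NC(C)(C)C)ccc2n1Cc1ccccc1`, gives 160 nM in an assay on isolated protein for inhibition of Gonadotropin-releasing hormone receptor (Rattus norvegicus); on this read-out lower numbers stand for stronger inhibition and higher numbers for weaker inhibition. Compound 2, `COc1ccc([N+](=O)[O-])cc1CSc1nc2cc(NC(=O)NC(C)(C)C)ccc2n1Cc1ccncc1`, differs from it by pyridin-4-yl in place of phenyl on a saturated chain carbon bound to an aromatic nitrogen and gives 240 nM in this assay; the change made a 1.5-fold higher number from compound 1 to compound 2 (0.18 log units; within the scatter). Compound 3, `CCCn1c(SCc2cc([N+](=O)[O-])ccc2OC)nc2cc(NC(=O)NC(C)(C)C)cc(C(=O)NCc3ccccc3)c21`, gives 130 nM in this assay; the difference between its core and the core of compound 1 is not broken down here, so the two values are simply set side by side. Compound 4, `CCCn1c(SCc2cc([N+](=O)[O-])ccc2OC)nc2cc(NC(=O)NC(C)(C)C)cc(C(=O)NCc3ccncc3)c21`, has not been measured. It differs from compound 3 by pyridin-4-yl in place of phenyl on a saturated chain carbon bound to an amide-type nitrogen. This is the same kind of change as from compound 1 to compound 2, but the place is not the same: there the saturated chain carbon is bound to an aromatic nitrogen, here to an amide-type nitrogen. Since the earlier change made a 1.5-fold higher number from compound 1 to compound 2 (0.18 log units; within the scatter), a comparable small step, a 1.4-fold higher number from compound 3 to compound 4 (0.14 log units; within the scatter), is expected from compound 3 to compound 4 in this assay. Compound 4 is therefore estimated to give 180 nM, expected between 90 nM and 400 nM.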

Compound 4, half-maximal inhibitory concentration: 35 nM
Compound 4: the middle estimate sits 5.1-fold (0.71 log units) above what was measured; the whole stated range lies above it.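

In this assay, pyridin-4-yl in place of phenyl gave a 3.7-fold lower number from compound 3 to compound 4 (0.57 log units; beyond the scatter), and the result on one core did not predict the result on the other: the same change on two cores in this assay, a 1.5-fold higher number (0.18 log units; within the scatter) from compound 1 to compound 2 and a 3.7-fold lower number (0.57 log units; beyond the scatter) from compound 3 to compound 4, 5.6-fold (0.75 log units) apart, beyond the scatter of two such steps. The two pairs also differ in the place of the change, since the saturated chain carbon is bound to an aromatic nitrogen in one pair and to an amide-type nitrogen in the other, and they cannot separate the influence of the core from that of the place. Among the compounds shown here, with only one pair for each place, the data show that this change cannot be assumed to carry across these cores, but they establish no rule for either place and give no reason for the gap.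

The compounds shown leave open whether a dimethylamino group or a carboxylic acid in place of pyridin-4-yl on that saturated chain carbon would match compound 4. They also leave open how a longer chain bearing pyridin-4-yl on the amide-type nitrogen would compare.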